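This account rests on a few compounds, and the source may have more. Where it says the series, first, only, none or still open, it means among the compounds named here.

Measured in a physicochemical assay for solubility; a higher number here means a more soluble compound, a lower number a less soluble compound:
- compound 1 `COc1cc(/C=C(/SCc2ccc(Br)cc2)C(=O)c2ccc(C(=O)O)cc2)ccc1F`: < 1000 ug/mL (a limit)
- compound 2 `O=C(O)c1ccc(C(=O)/C(=C\c2ccc(F)c([N+](=O)[O-])c2)Sc2ccc(Br)cc2)cc1`: < 1000 ug/mL (a limit)

For the measured compounds named here, neither compound has a numerical solubility, so the series offers no measured step.

Compound 1 stands at < 1000 ug/mL, which is a limit and not a number. The overall position is the limit of < 1000 ug/mL in this assay, at which 2 of the 2 values shown sit.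

The next compound is compound 3 `O=C(O)c1ccc(C(=O)/C(=C\c2ccc(Cl)c([N+](=O)[O-])c2)SCc2ccc(Br)cc2)cc1`, which has the same core as compound 1 and differs in one place: 4-chloro-3-nitrophenyl in place of 4-fluoro-3-methoxyphenyl on a double-bonded chain carbon bound to a double-bonded chain carbon. It has 4-chloro-3-nitrophenyl in place of 4-fluoro-3-methoxyphenyl on a double-bonded chain carbon bound to a double-bonded chain carbon.

Going by the values given here, with no measured step to calibrate the change, no shift beyond the scatter is expected in this assay, and no direction can be assigned. This expectation has only weak support from compound 2, whose < 1000 ug/mL is also a limit. Compound 3 will most likely be reported as a limit too. The estimated change is a step that the limit leaves unreadable from compound 1 to compound 3. For compound 3 the expected value is 500 ug/mL, with an estimated range from 100 ug/mL to 1000 ug/mL.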

Compound 3, solubility: < 1000 ug/mL
Compound 3 gave a limit, no number (the forecaster's own chance of this, stated with the estimate: 85%); the middle value is on the limit's open side.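

Compound 1 and compound 3 are both reported only as limits in this assay, so exchanging 4-fluoro-3-methoxyphenyl for 4-chloro-3-nitrophenyl gives no readable step between them. The series remains at a single limit: the limit of < 1000 ug/mL in this assay, at which 3 of the 3 values shown sit.

The compounds shown leave open what numerical solubility any of them has, and whether the exchanged group alters it.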